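Swapping a Pyridylphenyl for Chlorophenyl on a Shared Core

This account rests on a few compounds, and the source may have more. Where it says the series, first, only, none or still open, it means among the compounds named here.

Of the compounds shown here, two have been measured in a functional assay on HeLa cells (Homo sapiens) for antiproliferative activity, read by CCK-8 assay, with a stated time of 72 h; a higher number here means a weaker inhibitor, a lower number a stronger inhibitor. Compound 1 `Nc1ccccc1NC(=O)c1ccc(Cn2cnc3c(Nc4ccc(-c5ccccn5)cc4)nc(Cl)nc32)cc1` carries a 4-(pyridin-2-yl)phenyl group on a nitrogen of its core. For compound 1 the result is a limit of the assay rather than a number, > 20000 nM, which corresponds to the limit of > 20000 nM in this assay, at which 1 of the 2 values shown sits. Among the compounds with values here, compound 2 `CCC(C)n1cnc2c(NCc3ccc(C(=O)Nc4ccccc4N)cc3)nc(Cl)nc21` is built on a related core with a different substitution pattern and gives 3030 nM in this assay; since it differs from compound 1 in more than one place, no single step can be drawn between them.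

Compound 3 `Nc1ccccc1NC(=O)c1ccc(Cn2cnc3c(Nc4cccc(Cl)c4)nc(Cl)nc32)cc1` is not yet measured. It differs from compound 1 in one place: 3-chlorophenyl in place of 4-(pyridin-2-yl)phenyl on a nitrogen on an aromatic ring. Compound 1 is known only as a limit, and the starting point of this change is open. Within the data shown here, the sole numerical anchor is compound 2 at 3030 nM. Compound 3 is expected to give roughly 10000 nM in this assay, with a plausible range from 2000 nM to 40000 nM. The expected step of an at least 2.0-fold lower number from compound 1 to compound 3 (0.30 log units; that floor lies within the scatter) would point toward stronger inhibition, but its true size cannot be fixed from a limit.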

Compound 3, half-maximal inhibitory concentration: 11300 nM
For compound 3 the middle estimate is 1.1-fold (0.05 log units) below the measured one, within the range that was stated.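

With compound 3, this place on the shared core gets its first real number: in this assay, compound 3 gives 11300 nM, so a group on this nitrogen can leave a compound with a readable result. Putting 3-chlorophenyl in place of 4-(pyridin-2-yl)phenyl on a nitrogen on an aromatic ring gives an at least 1.7-fold lower number from compound 1 to compound 3 (0.24 log units; that floor lies within the scatter), which points toward stronger inhibition, although the smaller, single-ring group still gives only a weak result on this scale. The step is a floor and not a measured size, and that floor cannot be told apart from ordinary scatter, because the value for compound 1 is a limit of the assay and not a number: the limit of > 20000 nM in this assay, at which 1 of the 3 values shown sits.

This single change removes a two-ring group and brings in a one-ring group carrying chlorine, so the compounds shown cannot say whether the loss of the pyridine ring, the arrival of the chlorine, or both account for the step. A plain phenyl group on the same nitrogen would help separate these two parts of the change, and a methoxy group in place of the chlorine would show whether chlorine itself matters.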